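Swapping chloro for trifluoromethyl on the phenyl ring

This account rests on a few compounds, and the source may have more. Where it says the series, first, only, none or still open, it means among the compounds named here.

Compound 1 `O=C(NCc1cc(C(F)(F)F)nn1-c1cccc(Cl)c1)Nc1cccc2[nH]ncc12` is the lower of the two measured numbers: in an assay on CHO-K1 cells for antagonist activity at transient receptor potential cation channel subfamily V member 1 (Homo sapiens), read by FLIPR and calcium flux, with a stated time of 6 min (a higher number here means a weaker inhibitor, a lower number a stronger inhibitor), compound 1 gives 0.9 nM, while compound 2 `Cn1ncc2c(NC(=O)NCc3cc(C(F)(F)F)nn3-c3cccc(Cl)c3)cccc21` gives 2.3 nM, a step of a 2.6-fold higher number from compound 1 to compound 2 (0.41 log units; beyond the scatter). Compound 3 `O=C(NCc1cc(C(F)(F)F)nn1-c1cccc(C(F)(F)F)c1)Nc1cccc2[nH]ncc12` differs from compound 1 by trifluoromethyl in place of chloro on an aromatic carbon. Among the measured compounds shown here, the one measured step concerns a methyl on an aromatic nitrogen, a different place, so no measured step bears on this change, and a step of a 1.3-fold higher number from compound 1 to compound 3 (0.12 log units; within the scatter) that may stay within the scatter is expected. Compound 3 is estimated at 1.2 nM, between 0.4 nM and 4 nM.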

Compound 3, inhibition constant: 1.3 nM
Beside the measured number, compound 3's estimate is 1.1-fold (0.03 log units) below it; low and high end bracket the measured number.
By their numbers in this assay, from the lowest: compounds 1, 3 and 2 (each within the scatter of the next, the first and the last beyond it).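

In this assay the change from chloro to trifluoromethyl gives a 1.4-fold higher number from compound 1 to compound 3 (0.16 log units; within the scatter) and is the first step shown on the phenyl ring rather than on an aromatic nitrogen. A group of 4 heavy atoms can therefore take the place of a single chlorine atom at this position without a change beyond the scatter. This position does not depend on chloro, at least where trifluoromethyl is the alternative.

Going by these compounds, whether a methoxy group, an amine or a plain hydrogen would be tolerated at this position remains open. Nothing shown gives a reason why chloro and trifluoromethyl read alike here.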